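Swapping an aryl group for a pyridyl thioether

A few compounds are considered here, and "the series" means these few. Any claim that something is new, unique, unknown or untested is made for them only; others in the source may bear on it.

Measured compounds:
- compound 1 `Cc1cc(Br)c(S(C)(=O)=O)cc1C(=O)N=C(N)N`: 12 nM
- compound 2 `CCc1cc(Br)c(S(C)(=O)=O)cc1C(=O)N=C(N)N`: 41 nM
- compound 3 `Cc1cc(-c2ccc(Cl)cc2Cl)c(S(C)(=O)=O)cc1C(=O)N=C(N)N`: 42 nM

The three measured compounds share one core and were tested in a functional assay for inhibition of sodium/hydrogen exchanger (Oryctolagus cuniculus); on this read-out higher numbers stand for weaker inhibition and lower numbers for stronger inhibition. Compound 3 gives the highest of the three numbers, with 42 nM. The gap to compound 2 is a 3.4-fold higher number from compound 1 to compound 2 (0.53 log units; beyond the scatter) set against a 3.5-fold higher number from compound 1 to compound 3 (0.54 log units; beyond the scatter); the two values are within the scatter of each other. Compound 1 stands apart as the lowest number.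

Compound 4 `Cc1cc(Sc2ccncc2)c(S(C)(=O)=O)cc1C(=O)N=C(N)N` is derived from compound 3 by a change at the same position that was altered from compound 1 to compound 3: (pyridin-4-yl)sulfanyl in place of 2,4-dichlorophenyl on an aromatic carbon. Going by the values given here, the only measured step that touches this position is the one from compound 1 to compound 3, which moved the number upward by a 3.5-fold higher number from compound 1 to compound 3 (0.54 log units; beyond the scatter). Among the compounds with values here, no measured step exchanges one aromatic group for another at this site, so the direction of the new step has no direct precedent. Since compound 3 already carries a ring there, the group entering in compound 4 is expected to leave the number close to where compound 3 stands, with a step of a 1.1-fold higher number from compound 3 to compound 4 (0.03 log units; within the scatter), not beyond the scatter. Compound 4 is therefore estimated at 45 nM, within 15 nM to 135 nM.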

Compound 4, half-maximal inhibitory concentration: 13 nM
Estimate against measurement, compound 4: 3.5-fold (0.54 log units) above, outside the stated range (below it).
By their numbers in this assay, from the lowest: compounds 1 and 4 (each within the scatter of the next); then compounds 2 and 3 (each within the scatter of the next).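

Going by these compounds alone, at the position ortho to a methylsulfonyl group, in this assay, exchanging 2,4-dichlorophenyl for (pyridin-4-yl)sulfanyl gives a 3.2-fold lower number from compound 3 to compound 4 (0.51 log units; beyond the scatter) and so is the first measured step between two ring-bearing groups at this site; a ring at this position therefore need not carry the higher number seen with compound 3. The comparison with bromo gives a 1.1-fold higher number from compound 1 to compound 4 (0.03 log units; within the scatter) and places (pyridin-4-yl)sulfanyl level with bromo on this read-out, so the site accepts at least one ring-bearing group without a measurable cost relative to bromo. Nothing available accounts for the difference between the two ring-bearing groups.

The compounds shown leave open which part of the change matters, since the sulfur link, the ring nitrogen and the loss of both chlorine atoms enter together in the single step between the two compounds. A phenylsulfanyl group, a pyridin-4-yl ring bound directly to the core, or a pyridin-2-yl or pyridin-3-yl sulfanyl group at this position would be needed to pull these parts apart.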